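The compounds below may be only part of what the source reports. "The series", "measured", "known", "first", "only" and "open" are said of these compounds alone.

Measured compounds:
- Compound 2, `CCCCSc1nc(NC2CCCCC2)c2ncn([C@@H]3O[C@H](CO)[C@@H](O)[C@H]3O)c2n1`: 83000 nM
- Compound 1, `CCSc1nc(NC(C)c2ccccc2)c2ncn([C@@H]3O[C@H](CO)[C@@H](O)[C@H]3O)c2n1`: 197000 nM

In a functional assay on a cell-free system (Platelet, plasma, Homo sapiens) for inhibition, with stated times of 1 min and 3 min (a higher number here means a weaker inhibitor, a lower number a stronger inhibitor), compound 2 gives the lower of the two numbers, 83000 nM, and so stands as the stronger inhibitor of the pair. In this assay compound 1 gives 197000 nM, a higher number, and the gap between the two lies beyond the usual scatter of repeated measurements. Compound 1 and compound 2 differ in more than one place at once, so the two values say only how the two whole molecules compare, not what any single change does.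

Compound 3, `CCCSc1nc(NC2CCCCC2)c2ncn([C@@H]3O[C@H](CO)[C@@H](O)[C@H]3O)c2n1`, has not yet been measured in this assay. Compared with compound 2 the difference is hydrogen in place of methyl on a saturated chain carbon, three bonds along the chain from a sulfur. Among the measured compounds shown here, no pair of measured compounds isolates a change of this kind, so there is no measured step to lean on. With one carbon less on the chain, a small step from compound 2 to compound 3 of a 1.4-fold higher number from compound 2 to compound 3 (0.16 log units; within the scatter) toward a somewhat higher number is expected, possibly no larger than the scatter. For compound 3 the estimate is 120000 nM, with a likely range from 50000 nM to 300000 nM.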

Compound 3, half-maximal inhibitory concentration: 151000 nM
For compound 3 the middle estimate is 1.3-fold (0.10 log units) below the measured one; the measured number falls inside the stated range.
By their numbers in this assay, from the lowest: compounds 2, 3 and 1 (each within the scatter of the next, the first and the last beyond it).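

The step gives the first measured read on this position: in this assay, replacing the butyl chain of compound 2 with the propyl chain of compound 3 amounts to a 1.8-fold higher number from compound 2 to compound 3 (0.26 log units; within the scatter). Because that step stays within the scatter, the two compounds cannot be told apart in this assay, so removing this one carbon has no effect that can be distinguished from ordinary variation between repeated measurements. No other measurement available here bears on this result.

Only this single change in chain length has been isolated, so the compounds shown do not reveal whether a longer chain, such as pentyl, or a chain carrying a hydroxyl group or a carboxylic acid, would produce a step beyond the scatter. Compound 1 carries an ethyl chain but also differs elsewhere, so it cannot show whether shortening the chain further, with all else held the same, would leave the number just as indistinguishable.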